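Removing the methylene linker from the triazole arm

The compounds below may be only part of what the source reports. "The series", "measured", "known", "first", "only" and "open" are said of these compounds alone.

Among the measured compounds shown here, in an assay on CHO cells for displacement of a labelled ligand from 5-hydroxytryptamine receptor 1B (Homo sapiens) (on this read-out lower numbers stand for stronger inhibition and higher numbers for weaker inhibition), compound 1 `OC[C@H](NC1CCN(CCCc2c[nH]c3ccc(-n4ccnc4)cc23)CC1)c1ccccc1` gives 100 nM, while compound 2 `OC[C@H](NC1CCN(CCCc2c[nH]c3ccc(Cn4cncn4)cc23)CC1)c1ccccc1` gives 1300 nM, the higher of the two numbers so far, the step being a 13-fold higher number from compound 1 to compound 2 (1.11 log units; beyond the scatter). Compound 3 `OC[C@H](NC1CCN(CCCc2c[nH]c3ccc(-n4cncn4)cc23)CC1)c1ccccc1` differs from compound 2 by 1H-1,2,4-triazol-1-yl in place of (1H-1,2,4-triazol-1-yl)methyl on an aromatic carbon. For the measured compounds named here, only the step from compound 1 to compound 2 bears on this, and it changed both the ring and the linker at once, so the separate weight of the linker is unknown. Compound 3 is expected to return part of the way toward compound 1, an estimated step of a 5.2-fold lower number from compound 2 to compound 3 (0.72 log units; beyond the scatter). The estimate for compound 3 is 250 nM, ranging from 70 nM to 900 nM.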

Compound 3, half-maximal inhibitory concentration: 400 nM
Compound 3: middle estimate off by 1.6-fold (0.20 log units), on the low side; the measured number falls inside the stated range.
By their numbers in this assay, from the lowest: compound 1; then compound 3; then compound 2.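

In this assay, removing the methylene linker alone gives a 3.3-fold lower number from compound 2 to compound 3 (0.51 log units; beyond the scatter) and so accounts for part of the earlier loss. Among the compounds shown here, with no linker on either compound, 1H-1,2,4-triazol-1-yl in place of 1H-imidazol-1-yl gives a 4.0-fold higher number from compound 1 to compound 3 (0.60 log units; beyond the scatter) and shows that the ring itself also counts at this position. The compounds shown leave open how the 1H-imidazol-1-yl ring would fare on a methylene linker, and how an amide or a nitrile would compare at this place. No measured evidence explains either step.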